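A few compounds are considered here, and "the series" means these few. Any claim that something is new, unique, unknown or untested is made for them only; others in the source may bear on it.

Compound 2 `O=C(Nc1cnc(-n2nccn2)c(Cl)c1)Nc1cnc2cc(Cl)nn2c1C1CC1` stands at a limit in an ADME assay on microsomes from liver (Homo sapiens) for metabolic stability; on this read-out lower numbers stand for slow clearance and higher numbers for fast clearance: < 25 mL.min-1.g-1, which is not a number. Compound 3 `CO[C@@H](C)c1c(NC(=O)Nc2cnc(-n3nccn3)c(Cl)c2)cnc2cc(Cl)nn12` also gives only a limit, < 25 mL.min-1.g-1. The readings at hand therefore rest largely on (the limit of < 25 mL.min-1.g-1 in this assay, at which 2 of the 3 values shown sit). Among the compounds with values here, compound 1 `CC(C)c1c(NC(=O)Nc2ccnc(C(F)(F)F)c2)cnc2cc(Cl)nn12` gives an actual number, 61 mL.min-1.g-1, but it differs from compound 2 in more than one place, so no single step connects them.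

Compound 4 `O=C(Nc1cnc(-n2nccn2)c(Cl)c1)Nc1cnc2cc(Cl)nn2c1C1CCOCC1` carries the change oxan-4-yl in place of cyclopropyl on an aromatic carbon, next to the ring nitrogen. Within the data shown here, the one measured step at this place is a step that the two limits leave unreadable from compound 2 to compound 3, and it offers no size to carry over. Among the measured compounds shown here, its only guide is that compound 3 remained at a limit, < 25 mL.min-1.g-1, after cyclopropyl was replaced. No step beyond the scatter is therefore expected in this assay, and no direction can be assigned. The expected step is a step that the limit leaves unreadable from compound 2 to compound 4. For compound 4 the estimated value is 23 mL.min-1.g-1, with an expected range from 12 mL.min-1.g-1 to 48 mL.min-1.g-1.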

Compound 4, intrinsic clearance in microsomes: < 25 mL.min-1.g-1
Compound 4: no number, only a limit; the forecaster's own chance of this, stated with the estimate: 60%; the middle value is on the limit's open side.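

Within the data shown here, compound 4 also stands at a limit in this assay and so no step among compound 2, compound 3 and compound 4 can be read; the readings rest on one limit: the limit of < 25 mL.min-1.g-1 in this assay, at which 3 of the 4 values shown sit.
On these data alone, whether cyclopropyl, 1-methoxyethyl and oxan-4-yl differ at all in this assay stays open.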